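Anilino variants on the shared core: outlook for compound 4

The source may hold more compounds than are shown below. What is called first, only, known or untested is meant among the compounds shown, and "the series" means these compounds.

Measured compounds:
Compound 1, `Cc1ccc(NC2=CC(=O)c3nc4n(c3C2=O)[C@H]2OC[C@@H](O)[C@H]2OC4)cc1`: in a functional assay on ECa-109 cells for inhibition, with ECa-109 cell line (Homo sapiens) as the target, read by sulforhodamine B assay (on this read-out lower numbers stand for stronger inhibition and higher numbers for weaker inhibition), compound 1 gives 3480 nM.
Compound 2, `O=C1C=C(NCc2ccccc2)C(=O)c2c1nc1n2[C@H]2OC[C@@H](O)[C@H]2OC1`: in this assay compound 2 reaches only the assay limit of > 8000 nM.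
Compound 3, `COc1cccc(NC2=CC(=O)c3nc4n(c3C2=O)[C@H]2OC[C@@H](O)[C@H]2OC4)c1`: in this assay compound 3 gives 7620 nM.

Compound 3 stands at the highest of the two numbers, with compound 1 nearest, shown by a 2.2-fold higher number from compound 1 to compound 3 (0.34 log units; beyond the scatter). One of the three values is the limit of > 8000 nM in this assay, at which 1 of the 3 values shown sits, so the step of an at least 1.0-fold lower number from compound 2 to compound 3 (0.02 log units; that floor lies within the scatter) is a floor only and says nothing beyond the scatter.

Compound 4, `CCc1ccc(NC2=CC(=O)c3nc4n(c3C2=O)[C@H]2OC[C@@H](O)[C@H]2OC4)cc1`, awaits measurement. The change from compound 3 is 4-ethylphenyl in place of 3-methoxyphenyl on an amine nitrogen. The step that bears on it is a 2.2-fold higher number from compound 1 to compound 3 (0.34 log units; beyond the scatter), which runs from a 4-methylphenyl on the amine nitrogen to 3-methoxyphenyl; the step to compound 4 reverses this, returning to a 4-alkylphenyl, now 4-ethylphenyl. The step of an at least 2.2-fold higher number from compound 1 to compound 2 (0.36 log units; beyond the scatter) concerns benzyl and does not bear directly. On this basis a modest lower number is expected in this assay, about a 2.0-fold lower number from compound 3 to compound 4 (0.30 log units; within the scatter), landing close to compound 1. Compound 4 is therefore expected to give about 3800 nM in this assay, estimated between 1500 nM and 9000 nM.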

Compound 4, half-maximal inhibitory concentration: 3080 nM
Estimate against measurement, compound 4: 1.2-fold (0.09 log units) above; the range from low to high includes it.
By their numbers in this assay, from the lowest: compounds 4 and 1 (each within the scatter of the next); then compound 3. At a limit, above all of these: compound 2.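

In this assay, going from 4-methylphenyl to 4-ethylphenyl on the amine nitrogen gives a 1.1-fold lower number from compound 1 to compound 4 (0.05 log units; within the scatter), so adding one methyl to the chain leaves the number unchanged within the scatter. Against the 3-methoxyphenyl group, the same position now shows a 2.5-fold lower number from compound 3 to compound 4 (0.39 log units; beyond the scatter), so both the 4-methylphenyl and the 4-ethylphenyl compounds read lower than compound 3, a comparison that previously rested on compound 1 alone. The comparison with benzyl reads as an at least 2.5-fold lower number from compound 2 to compound 4 (0.41 log units; beyond the scatter), which is a floor only: the limit of > 8000 nM in this assay, at which 1 of the 4 values shown sits.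

Still open, as far as these compounds go, is whether a longer chain such as 4-butylphenyl, or a carboxylic acid on the phenyl ring, would keep the number in the range of compound 1 and compound 4. Also open, from the compounds shown here alone, is whether the higher number of compound 3 goes with the methoxy group itself or with where it sits on the ring, a question that 4-methoxyphenyl and 3-ethylphenyl on the same amine nitrogen could separate.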